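A few compounds are considered here, and "the series" means these few. Any claim that something is new, unique, unknown or untested is made for them only; others in the source may bear on it.

Compound 1 `O=S(=O)(Nc1ccc2oc(-c3ccccc3)nc2c1)c1cccs1` gives 90000 nM in an assay on cells for inhibition of HSP60/HSP10 (Homo sapiens), with a stated time of 60 min; on this read-out higher numbers stand for weaker inhibition and lower numbers for stronger inhibition.
Compound 2 `O=S(=O)(Nc1ccc(-c2nc3ccccc3o2)cc1)c1ccc(C(F)(F)F)cc1` gives 50000 nM in this assay.
Compound 3 `O=S(=O)(Nc1ccc2oc(-c3ccccc3)nc2c1)c1ccc(O)cc1` gives 88000 nM in this assay.

Compound 3 holds the second highest of the three numbers; compound 1 sits within the scatter of it, and compound 2 as well, so no order among the three can be read. Compound 4 `COc1ccc(S(=O)(=O)Nc2ccc3oc(-c4ccccc4)nc3c2)cc1` differs from compound 3 by methyl in place of hydrogen on an oxygen on an aromatic ring. Among the measured compounds shown here, the only measured step that varies the group on the sulfonyl sulfur, a 1.0-fold lower number from compound 1 to compound 3 (0.01 log units; within the scatter), stayed within the scatter, and no measured pair tests hydroxy against methoxy. The step from compound 3 to compound 4 is therefore expected to stay within the scatter, in no direction, a 1.0-fold lower number from compound 3 to compound 4 (0.02 log units; within the scatter). Compound 4 is estimated at 85000 nM, between 40000 nM and 180000 nM.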

Compound 4, half-maximal inhibitory concentration: > 100000 nM
Compound 4 gave a limit, no number (the forecaster's own chance of this, stated with the estimate: 30%); middle value at least 1.1-fold (0.07 log units) away from the limit.
By their numbers in this assay, from the lowest: compounds 2, 3 and 1 (each within the scatter of the next). At a limit, above all of these: compound 4.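

In this assay, compound 4 gives a limit and not a number: the limit of > 100000 nM in this assay, at which 1 of the 4 values shown sits. Hydroxy to methoxy on the aryl group on the sulfonyl sulfur gives an at least 1.1-fold higher number from compound 3 to compound 4 (0.05 log units; that floor lies within the scatter), and the exchange of thiophen-2-yl for 4-methoxyphenyl gives an at least 1.1-fold higher number from compound 1 to compound 4 (0.04 log units; that floor lies within the scatter). Both floors lie within the scatter, so this position has still shown no change beyond the scatter, though the true size of either step is unknown. The compounds shown leave open where compound 4's true value lies. They also leave open whether an amine or a carboxylic acid in place of the hydroxy would move the number beyond the scatter.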